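From 3-chloropropyl to 1-hydroxycyclohexyl on the shared core

A few compounds are considered here, and "the series" means these few. Any claim that something is new, unique, unknown or untested is made for them only; others in the source may bear on it.

In a functional assay on MDA-MB-231 cells (Homo sapiens) for antiproliferative activity, read by sulforhodamine B assay, with a stated time of 48 h (on this read-out higher numbers stand for weaker inhibition of growth and lower numbers for stronger inhibition of growth), compound 3 `O=C1COc2ccccc2N1CCCn1cc(CCCCl)nn1` gives 6400 nM, the middle of three numbers. Compound 2 `CCCc1cn(CCCN2C(=O)COc3ccccc32)nn1` gives 1100 nM, and compound 1 `COc1ccc(-c2cn(CCCN3C(=O)COc4ccccc43)nn2)cc1` gives 41500 nM. Compound 4 `O=C1COc2ccccc2N1CCCn1cc(C2(O)CCCCC2)nn1` differs from compound 3 at one place: 1-hydroxycyclohexyl in place of 3-chloropropyl on an aromatic carbon. Among the measured compounds shown here, three measured steps bear on this change. Two replace the group on the same aromatic carbon, a 38-fold lower number from compound 1 to compound 2 (1.58 log units; beyond the scatter) and a 6.5-fold lower number from compound 1 to compound 3 (0.81 log units; beyond the scatter), and one alters the chain there, a 5.8-fold higher number from compound 2 to compound 3 (0.76 log units; beyond the scatter). For the measured compounds named here, no measured compound carries a 1-hydroxycyclohexyl group, so the data support no direction, and no step beyond the scatter is expected. The expected change is a 1.1-fold higher number from compound 3 to compound 4 (0.04 log units; within the scatter). Compound 4 is estimated at 7000 nM, with an expected range from 2000 nM to 25000 nM.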

Compound 4, concentration for 50% growth inhibition: 1200 nM
Compound 4: middle estimate off by 5.8-fold (0.77 log units), on the high side; the whole stated range lies above it.
By their numbers in this assay, from the lowest: compounds 2 and 4 (each within the scatter of the next); then compound 3; then compound 1.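

Of the groups shown on this aromatic carbon, 1-hydroxycyclohexyl is the only one with a non-aromatic ring, and it gives a 5.3-fold lower number from compound 3 to compound 4 (0.73 log units; beyond the scatter) and a 35-fold lower number from compound 1 to compound 4 (1.54 log units; beyond the scatter). Against the plain chain it gives a 1.1-fold higher number from compound 2 to compound 4 (0.04 log units; within the scatter), so this position accepts a ring of carbon carrying a hydrogen-bond donor with no measurable loss relative to propyl. Nothing available explains why these groups differ. Going by these compounds, it remains open whether plain cyclohexyl, without the hydroxyl, would match compound 4. An amine or a carboxylic acid on this carbon is also untested among the compounds shown.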